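This account rests on a few compounds, and the source may have more. Where it says the series, first, only, none or still open, it means among the compounds named here.

Measured compounds:
- compound 1 `Cn1ncnc1-c1ccccc1NCC1=NCCN1`: 2 nM
- compound 2 `CCn1nccc1-c1ccccc1NCC1=NCCN1`: 63.1 nM

In an in vitro functional assay on cells (Fibroblast) for agonist activity at Alpha-1A adrenergic receptor (Homo sapiens) (a higher number here means that more compound is needed for the effect, a lower number that less compound is needed), compound 1 gives 2 nM, and compound 2 gives 63.1 nM. Compound 2 thus stands at the higher of the two numbers, and the gap to compound 1 lies beyond the scatter. The two compounds differ in more than one place, so no single change can be read from that gap.

Compound 3 `CC(C)n1nccc1-c1ccccc1NCC1=NCCN1` is not yet measured. It differs from compound 2 by methyl in place of hydrogen on a saturated chain carbon bound to an aromatic nitrogen and a saturated chain carbon, which reads, cut one bond further out, as ethyl to isopropyl. Among the measured compounds shown here, no pair of measured compounds isolates a change of this kind. Since compound 2 already gives 63.1 nM and the growth continues in the same direction, a moderate rise in this assay is expected, though a step within the scatter cannot be excluded. The step from compound 2 to compound 3 is estimated at a 2.4-fold higher number from compound 2 to compound 3 (0.38 log units; beyond the scatter). Compound 3 is expected to give 150 nM, within 40 nM to 600 nM.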

Compound 3, half-maximal effective concentration: < 100000 nM
Compound 3: no number, only a limit; the forecaster's own chance of this, stated with the estimate: 5%; the middle value is on the limit's open side.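

In this assay compound 3 gives < 100000 nM, which is a limit and not a number. Among the compounds shown here, no step from compound 2 to compound 3 can be read from it. The compounds shown leave open the size and direction of the change from ethyl to isopropyl in this assay.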